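Removing the Basic Side Chain from Compound 1

The compounds below may be only part of what the source reports. "The series", "measured", "known", "first", "only" and "open" are said of these compounds alone.

Among the compounds with values here, compound 1 `O=C1c2c[n+]([O-])c3ccccc3c2C(=O)c2c1c1ccccc1n2CCN1CCCC1` gives 520 nM in a functional assay on SH-SY5Y cells (Homo sapiens) for cytotoxicity, read by MTT assay, with a stated time of 72 h (on this read-out lower numbers stand for stronger inhibition and higher numbers for weaker inhibition), the lowest of the two numbers measured so far. Within the data shown here, its only measured neighbour, compound 2 `CCCN1CCN(CCCCn2c3c(c4ccccc42)C(=O)c2c[n+]([O-])c4ccccc4c2C3=O)CC1`, gives 3970 nM in this assay, and the step between them is a 7.6-fold higher number from compound 1 to compound 2 (0.88 log units; beyond the scatter). Compound 3 `O=C1c2c[n+]([O-])c3ccccc3c2C(=O)c2[nH]c3ccccc3c21` has not yet been measured. It differs from compound 1 in one place: hydrogen in place of 2-(pyrrolidin-1-yl)ethyl on an aromatic nitrogen. Among the measured compounds shown here, the single measured step bears on this change only indirectly: it shows that exchanging one amine-bearing chain on the same aromatic nitrogen for another gave a higher number, whereas compound 3 carries no such chain at all. For the measured compounds named here, nothing measured so far shows directly what the bare aromatic nitrogen does. Resting on the one available step, the loss of the 2-(pyrrolidin-1-yl)ethyl is expected to raise the number, with a step of a 5.8-fold higher number from compound 1 to compound 3 (0.76 log units; beyond the scatter) that is expected to be of moderate size and carries wide uncertainty. Compound 3 is therefore estimated at 3000 nM in this assay, within a range from 800 nM to 12000 nM.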

Compound 3, half-maximal inhibitory concentration: 1380 nM
Compound 3: the middle estimate sits 2.2-fold (0.34 log units) above what was measured; the range from low to high includes it.
By their numbers in this assay, from the lowest: compound 1; then compound 3; then compound 2.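

Removing the 2-(pyrrolidin-1-yl)ethyl from the aromatic nitrogen gives a 2.7-fold higher number from compound 1 to compound 3 (0.42 log units; beyond the scatter) in this assay, so a cytotoxic read-out remains without this chain, although compound 1 does give the lower number. The earlier step could not show how an amine-bearing chain compares with hydrogen at this position, and here the answer depends on the chain: compound 1 lies below compound 3, which gives 1380 nM, while compound 2 gives a higher 3970 nM. So an amine-bearing chain on this nitrogen can go with either a lower or a higher number than hydrogen, and nothing available accounts for this difference.

The compounds shown leave open whether the step from hydrogen to the 2-(pyrrolidin-1-yl)ethyl follows the amine or the carbon chain alone, a question that a plain ethyl or a 2-hydroxyethyl on the same aromatic nitrogen would separate. They also leave open how chain length and the kind of amine act apart, which a 4-(pyrrolidin-1-yl)butyl or a 2-(piperidin-1-yl)ethyl on that nitrogen would begin to address.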